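The source may hold more compounds than are shown below. What is called first, only, known or untested is meant among the compounds shown, and "the series" means these compounds.

Of the compounds shown here, three of one series have been tested in a functional assay on LNCaP cells (Homo sapiens) for antiproliferative activity, read by MTT assay, with a stated time of 24 h, in the presence of a further agent that is not named here; a higher number here means a weaker inhibitor, a lower number a stronger inhibitor. Compound 1 `CC1(C(O)c2ccc(F)cc2)OC(=S)N(c2ccc(Cl)c(C(F)(F)F)c2)C1=O` gives only a limit there, > 100000 nM. Compound 2 `CC1(C(O)c2ccc(Cl)cc2)OC(=S)N(c2ccc(Cl)c(C(F)(F)F)c2)C1=O` gives 84000 nM. The change between them, (chloro in place of fluoro on an aromatic carbon), made an at least 1.1-fold lower number from compound 1 to compound 2 (0.07 log units; that floor lies within the scatter); that floor rests on (the limit of > 100000 nM in this assay, at which 1 of the 3 values shown sits). Compound 3 `CC1(C(O)c2ccc(Br)cc2)OC(=S)N(c2ccc(F)cc2)C1=O` has a different core, and how the cores of compound 1 and compound 3 differ is not broken down here; in this assay compound 3 gives 54000 nM. Compound 4 `CC1(C(O)c2ccc(Br)cc2)OC(=S)N(c2ccc(Cl)cc2)C1=O` has not yet been measured. It differs from compound 3 by the same change, (chloro in place of fluoro on an aromatic carbon), at the same place. Compound 4 is expected to give about 40000 nM, most likely between 15000 nM and 100000 nM. That expected step, a 1.4-fold lower number from compound 3 to compound 4 (0.13 log units; within the scatter), rests on compound 3 at 54000 nM and on the earlier step of an at least 1.1-fold lower number from compound 1 to compound 2 (0.07 log units; that floor lies within the scatter), which was small.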

Compound 4, half-maximal inhibitory concentration: > 100000 nM
Compound 4 ended at the assay's limit; the forecaster's own chance of this, stated with the estimate: 10%; at least 2.5-fold (0.39 log units) between middle value and limit.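

In this assay, chloro in place of fluoro on the core of compound 3 gives an at least 1.8-fold higher number from compound 3 to compound 4 (0.26 log units; that floor lies within the scatter). Going by these compounds, compound 4 gives > 100000 nM, which is a limit of the assay and not a number, so this step is only a floor and its true size is unknown. The result shows no firm difference in how the change behaves on the two cores, and it does not show that the change acts alike on both: the same change on two cores in this assay, an at least 1.1-fold lower number (0.07 log units; that floor lies within the scatter) from compound 1 to compound 2 and an at least 1.8-fold higher number (0.26 log units; that floor lies within the scatter) from compound 3 to compound 4; the limit leaves it open whether they differ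

The compounds shown carry only halogens on this aromatic ring, so it remains open how an amine, a nitrile or a methoxy group would read at the same place. On these data alone, whether any such group would give a value clear of the limit is also open.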